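The compounds below may be only part of what the source reports. "The series", "measured", "known", "first", "only" and "open" are said of these compounds alone.

Measured compounds:
compound 1 `CCCOc1ccc(C(=O)Nc2cccc(CC)n2)cc1` with 37600 nM
compound 2 `CCCCNc1cccc(NC(=O)c2ccc(OCCC)cc2)n1` with 54100 nM

Compound 2 gives the higher of the two numbers in an in vitro assay on HEK-tsA201 cells for antagonist activity at Neuronal acetylcholine receptor; alpha4/beta2 (Homo sapiens), read by fluorescence and calcium flux (a higher number here means a weaker inhibitor, a lower number a stronger inhibitor), but its step from compound 1 is small: a 1.4-fold higher number from compound 1 to compound 2 (0.16 log units; within the scatter). Compound 3 `CCCCCCNc1cccc(NC(=O)c2ccc(OCCC)cc2)n1` differs from compound 2 by ethyl in place of hydrogen on a saturated chain carbon, four bonds along the chain from a nitrogen on an aromatic ring. Going by the values given here, no measured step lengthens this chain; the only step at hand, from compound 1 to compound 2, swaps a different group and stays within the scatter. With nothing pointing either way, no step beyond the scatter is expected in this assay, so a 1.1-fold lower number from compound 2 to compound 3 (0.03 log units; within the scatter) is the expected step. Compound 3 is therefore estimated at 50000 nM, between 20000 nM and 130000 nM.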

Compound 3, half-maximal inhibitory concentration: > 100000 nM
Compound 3 ended at the assay's limit (the forecaster's own chance of this, stated with the estimate: 25%); middle value at least 2.0-fold (0.30 log units) away from the limit.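

Compound 3 sits at a limit of this assay, not at a measured number: the limit of > 100000 nM in this assay, at which 1 of the 3 values shown sits. Going from butylamino to hexylamino gives an at least 1.8-fold higher number from compound 2 to compound 3 (0.26 log units; that floor lies within the scatter), so this floor alone cannot separate the two chains. Going from ethyl to hexylamino on the aromatic carbon gives an at least 2.6-fold higher number from compound 1 to compound 3 (0.42 log units; beyond the scatter), the first step here to clear the scatter, which shows that this position does not accept every chain equally.

Going by these compounds, how a longer chain would read remains open, since compound 3 already sits at the limit. So does the effect of a carboxylic acid or a cyclic amine at this position.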